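The source may hold more compounds than are shown below. What is called first, only, known or untested is meant among the compounds shown, and "the series" means these compounds.

In a functional assay for inhibition, with Homo sapiens as the target (on this read-out lower numbers stand for tighter binding and higher numbers for weaker binding), compound 1 `O=C(O)CC/C=C\CC1COC(c2ccc(C(F)(F)F)cc2)OC1c1cccnc1` gives 1780 nM, compound 2 `CC(C)(Oc1ccccc1)C1OCC(C/C=C\CCC(=O)O)C(c2cccnc2)O1` gives 75.9 nM, and compound 3 `CSc1ccc(OC(C)(C)C2OCC(C/C=C\CCC(=O)O)C(c3cccnc3)O2)c([N+](=O)[O-])c1` gives 4.47 nM, the lowest number of the three. Compound 4 `Cc1ccc(C#N)c(OC(C)(C)C2OCC(C/C=C\CCC(=O)O)C(c3cccnc3)O2)c1` differs from compound 3 at one place: a group of 9 heavy atoms (8 carbon, 1 nitrogen; one six-membered aromatic ring of carbon only) in place of a group of 11 heavy atoms (7 carbon, 1 nitrogen, 2 oxygen, 1 sulfur; one six-membered aromatic ring of carbon only), on an oxygen on a saturated carbon. The measured step at this place, a 17-fold lower number from compound 2 to compound 3 (1.23 log units; beyond the scatter), was large. The other step, a 23-fold lower number from compound 1 to compound 2 (1.37 log units; beyond the scatter), was also large but lies elsewhere, on a saturated ring carbon, so it bears less directly. Among the measured compounds shown here, no measured compound carries the 2-cyano-5-methylphenyl group, so much of the earlier gain is expected to be kept, with a moderate rise in this assay. The estimated change is a 2.2-fold higher number from compound 3 to compound 4 (0.35 log units; beyond the scatter). For compound 4 the expected value is 10 nM, within an estimated range of 3 nM to 35 nM.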

Compound 4, dissociation constant: 15.9 nM
The estimate for compound 4 lay 1.6-fold (0.20 log units) below the measured number, within the range that was stated.
By their numbers in this assay, from the lowest: compound 3; then compound 4; then compound 2; then compound 1.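

Placed on the oxygen, the 2-cyano-5-methylphenyl group still improves on phenyl (a 4.8-fold lower number from compound 2 to compound 4 (0.68 log units; beyond the scatter)), so a second substituted ring, not only the one in compound 3, gives a lower number than plain phenyl at this position. The gain is not the same for both rings, however (a 3.6-fold higher number from compound 3 to compound 4 (0.55 log units; beyond the scatter)). No evidence on the cause of either step is at hand.

On these data alone, it remains open whether the nitrile, the methyl or both account for the step from phenyl, and where a ring bearing an amine or a chlorine atom would fall.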